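Swapping 3-chlorophenyl for 4-bromophenyl

The source may hold more compounds than are shown below. What is called first, only, known or untested is meant among the compounds shown, and "the series" means these compounds.

In a functional assay, read by spectrophotometry, with a stated time of 30 min (on this read-out lower numbers stand for stronger inhibition and higher numbers for weaker inhibition), compound 1 (`CC(C)(C)c1cc(/C=C/C(=O)NCCC2CCN(Cc3ccc(F)cc3)CC2)cc(C(C)(C)C)c1O`) gives 57500 nM while compound 2 (`CC(C)(C)c1cc(/C=C/C(=O)NCCC2CCN(Cc3ccc(F)cc3F)CC2)cc(C(C)(C)C)c1O`) gives 62400 nM and compound 3 (`CC(C)(C)c1cc(/C=C/C(=O)NCCC2CCN(Cc3cccc(Cl)c3)CC2)cc(C(C)(C)C)c1O`) gives 83100 nM so compound 3 stands within the scatter of both others. The step to compound 4 (`CC(C)(C)c1cc(/C=C/C(=O)NCCC2CCN(Cc3ccc(Br)cc3)CC2)cc(C(C)(C)C)c1O`), not yet measured, is 4-bromophenyl in place of 3-chlorophenyl on a saturated chain carbon bound to an amine nitrogen in a ring with 4-bromophenyl in place of 3-chlorophenyl on a saturated chain carbon bound to an amine nitrogen in a ring. Three measured steps alter this same group: a 1.1-fold higher number from compound 1 to compound 2 (0.04 log units; within the scatter) then a 1.4-fold higher number from compound 1 to compound 3 (0.16 log units; within the scatter) and finally a 1.3-fold higher number from compound 2 to compound 3 (0.12 log units; within the scatter) with none leaving the scatter. Among the compounds with values here, no measured compound carries bromine, so the comparison remains indirect. On these three steps, no change beyond the scatter is expected in this assay and no direction can be assigned. The expected step is a 1.2-fold lower number from compound 3 to compound 4 (0.09 log units; within the scatter) and it would lie within the scatter. Compound 4 is expected at 68000 nM within an estimated range of 35000 nM to 130000 nM on present evidence.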

Compound 4, half-maximal inhibitory concentration: 85600 nM
For compound 4 the middle estimate is 1.3-fold (0.10 log units) below the measured one; measured number inside the range.
By their numbers in this assay, from the lowest: compounds 1, 2, 3 and 4 (each within the scatter of the next).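

Bromine at this position, on the benzyl group of the ring amine nitrogen, leaves the picture in this assay unchanged: the exchange for 3-chlorophenyl gives a 1.0-fold higher number from compound 3 to compound 4 (0.01 log units; within the scatter) and the exchange for 2,4-difluorophenyl gives a 1.4-fold higher number from compound 2 to compound 4 (0.14 log units; within the scatter). Even bromo in place of fluoro, the one change here confined to the halogen, gives a 1.5-fold higher number from compound 1 to compound 4 (0.17 log units; within the scatter), so all four halogenated compounds now stand within the scatter of the next, and a third halogen has added no separation among them. No evidence at hand bears on this result.

The step from 3-chlorophenyl to 4-bromophenyl alters the halogen and its place together, and 4-chlorophenyl would separate the two. The compounds shown also leave open whether this position responds to anything other than halogens, such as an unsubstituted phenyl, 4-methoxyphenyl or a carboxylic acid on the ring.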